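Methyl to chloro on the aromatic ring: working notes

The compounds below may be only part of what the source reports. "The series", "measured", "known", "first", "only" and "open" are said of these compounds alone.

Measured so far:
compound 1 `Cc1ccc(/C=N/NC(=S)N2CCNCC2)cc1` — 70000 nM
compound 2 `C/C(=N\NC(=S)N1CCNCC1)c1cccc([N+](=O)[O-])c1` — 62000 nM

In a functional assay on HL-60 cells (Homo sapiens) for antiproliferative activity, with a stated time of 48 h (a higher number here means a weaker inhibitor, a lower number a stronger inhibitor), compound 1 gives 70000 nM. Within the data shown here, compound 2, the only other measured member, gives 62000 nM. The two numbers lie within the usual scatter of each other, so compound 1 cannot be set apart from compound 2 on these data; both sit at the weak end of what this assay reports. Among the measured compounds shown here, no step between two measured compounds differing in a single place is available, so there is no measured reference for how a single substituent swap moves the number.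

Compound 3 `S=C(N/N=C/c1ccc(Cl)cc1)N1CCNCC1` is not yet measured. It differs from compound 1 as follows: chloro in place of methyl on an aromatic carbon — chloro in place of methyl on an aromatic carbon, para to a large group.

For the measured compounds named here, with no measured single-point step to lean on, the expected step is a 1.2-fold lower number from compound 1 to compound 3 (0.07 log units; within the scatter), that is, none beyond the scatter. On that basis compound 3 is estimated at 60000 nM, with a range from 20000 nM to 160000 nM.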

Compound 3, half-maximal inhibitory concentration: 69000 nM
Beside the measured number, compound 3's estimate is 1.2-fold (0.06 log units) below it, within the range that was stated.
By their numbers in this assay, from the lowest: compounds 2, 3 and 1 (each within the scatter of the next).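

In this assay, among these compounds, chloro in place of methyl on an aromatic carbon, para to a large group, gives a 1.0-fold lower number from compound 1 to compound 3 (0.01 log units; within the scatter) and provides the first measured single-place step. This step shows that, at this position on the six-membered aromatic ring, the read-out does not separate the methyl and chloro groups, even though the swap replaces one carbon with one chlorine and the counted hydrogen-bond donors, acceptors and net charge stay the same. No measured data bear on why the number stays within the scatter across this swap.

The compounds shown leave open whether a group of another kind at this position, such as an amine, a carboxylic acid or a longer alkyl chain, would move the number beyond the scatter. Compound 2 differs from compound 1 and compound 3 in more than one place, so the role of its nitro group and of the methyl on its imine carbon remains unresolved, as does whether the same swap elsewhere on the ring would give a comparable step.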